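A Pyridinylmethyl Amide Replaces the Methyl Ester

The compounds below may be only part of what the source reports. "The series", "measured", "known", "first", "only" and "open" are said of these compounds alone.

The shared core of compound 1 `COC(=O)c1ccc2ccc(C(=O)c3ccccc3)c-2cc1` carries a benzoyl group and a methyl ester. In a physicochemical assay for solubility, with a stated time of 24 h, at pH 2.2 (a lower number here means a less soluble compound, a higher number a more soluble compound), compound 1 gives < 1 ug/mL, which is a limit of the assay and not a number. Compound 2 `COC(=O)c1ccc2c(C(=O)c3ccccc3)cc(C(=O)c3ccccc3)c-2cc1` adds a second benzoyl group on an aromatic carbon. In this assay compound 2 gives < 1 ug/mL, again a limit rather than a number. The measured step from compound 1 to compound 2 in this assay is a step that the two limits leave unreadable from compound 1 to compound 2; both compounds sit at the limit of < 1 ug/mL in this assay, at which 2 of the 2 values shown sit, so its size cannot be read.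

Compound 3 `O=C(NCc1cccnc1)c1ccc2ccc(C(=O)c3ccccc3)c-2cc1` differs from compound 1 by ((pyridin-3-yl)methyl)amino in place of methoxy on a carbonyl carbon. Within the data shown here, no measured step touches this change, and the single measured step carries no readable size, so nothing measured here sets the direction or size of the step. Compound 1 stands only at a limit, which leaves the starting point itself open. The step from compound 1 to compound 3 in this assay is estimated as an at least 5.0-fold higher number from compound 1 to compound 3 (0.69 log units; beyond the scatter). Compound 3 is expected to give roughly 5 ug/mL in this assay, within a range from 0.5 ug/mL to 50 ug/mL.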

Compound 3, solubility: 70 ug/mL
The estimate for compound 3 lay 14-fold (1.15 log units) below the measured number; the measured number lies above the stated range.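

With the ((pyridin-3-yl)methyl)amino group on the carbonyl carbon, the series gains its first readable number in this assay: compound 3 gives 70 ug/mL. The one earlier step, which added a second benzoyl group, cannot be read, so the replacement of methoxy on this carbonyl carbon is the first change shown with a readable direction, an at least 70-fold higher number from compound 1 to compound 3 (1.84 log units; beyond the scatter), and that step is large. Its full size stays unknown because compound 1 stands at a limit and not at a number: the limit of < 1 ug/mL in this assay, at which 2 of the 3 values shown sit.

The compounds shown do not tell which part of the entering group goes with the step, the aromatic ring with its nitrogen or the amide hydrogen, and a benzylamino group or a dimethylamino group on the same carbonyl carbon would separate the two. On these data alone, it also stays open whether the ((pyridin-3-yl)methyl)amino group gives a step of this kind on the core of compound 2, which carries the second benzoyl group.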